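The source may report more compounds than this note shows. Statements on the series, on what has been measured and on what is new or still open speak of the compounds shown alone.

Measured so far:
Compound 1 `CCc1cc(C(C)=O)c(O)cc1OCCCCCCC(C)(C)C#N`, in an assay on isolated protein for inhibition of leukotriene B4 receptor 1 (Homo sapiens), tested at 10 uM (a lower number here means less inhibition, a higher number more inhibition at the concentration tested (going by the name of the read-out)), compound 1 gives 65%
Compound 2 `CCc1cc(C(C)=O)c(O)cc1OCCCCCC(C)(C)C(=O)O`, in this assay compound 2 gives 104%

Compound 2 stands highest of the two numbers, the step of a number 39 percentage points higher from compound 1 to compound 2 (beyond the scatter) setting it apart from compound 1 by more than the usual scatter. The next compound, compound 3 `CCc1cc(C(C)=O)c(O)cc1OCCCC(C)(C)C(N)=O`, has not yet been measured. Its change from compound 2 is 1-carbamoyl-1-methylethyl in place of 3-carboxy-3-methylbutyl on a saturated chain carbon, three bonds along the chain from an oxygen on an aromatic ring. Among the measured compounds shown here, only one measured step bears on this: the step of a number 39 percentage points higher from compound 1 to compound 2 (beyond the scatter), where swapping the nitrile end of the chain for a carboxylic acid raised inhibition strongly. Compound 3 moves the other way, giving up the carboxylic acid for an amide and shortening the chain, two alterations at once. For the measured compounds named here, a drop of moderate size in this assay is therefore expected, though the single supporting step leaves this uncertain. For compound 3 the estimate is 60%, between 30% and 90%, a step of a number 44 percentage points lower from compound 2 to compound 3 (beyond the scatter).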

Compound 3, a percentage reported as inhibition, at one concentration (the size of the read-out at that concentration, not a potency): 92%
Estimate against measurement, compound 3: 32 percentage points below, and the stated range ends below it.
By their numbers in this assay, from the lowest: compound 1; then compound 3; then compound 2.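

In this assay, a carboxylic acid at the chain end is not needed for a high number: with 1-carbamoyl-1-methylethyl in place of 3-carboxy-3-methylbutyl, the result is only a number 12 percentage points lower from compound 2 to compound 3 (beyond the scatter). The shorter chain ending in an amide also gives a clearly higher number than the longer chain ending in a nitrile, with a number 27 percentage points higher from compound 1 to compound 3 (beyond the scatter), so a nitrile end is not the only route to a moderate number, and the amide sits closer to the acid than to the nitrile. Nothing measured here gives a reason for either step.

Chain length and end group change together in both steps, so their separate contributions remain unknown. From the compounds shown here alone, it also remains open how a chain of this length would fare when ending in an amine or a hydroxyl group.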